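The source may hold more compounds than are shown below. What is called first, only, known or untested is meant among the compounds shown, and "the series" means these compounds.

Working notes on the series. Within the data shown here, in an assay on CHO cells for inhibition of sodium-dependent dopamine transporter (Homo sapiens), read by scintillation counting, with a stated time of 10 min, tested at 10 uM (a lower number here means less inhibition, a higher number more inhibition at the concentration tested (going by the name of the read-out)), compound 1 `Cc1ccc(C(O)CCN2CC=C(Cc3ccccc3)CC2)cc1` gives 30%, the lowest of the three numbers so far. Compound 2 `COc1ccc(C(O)CCN2CC=C(Cc3ccccc3)CC2)cc1OC` gives 61% in this assay, and compound 3 `OC(CCN1CCC(O)(Cc2ccccc2)CC1)c1csc2ccccc12` gives 64%; both sit beyond the scatter above compound 1. Compound 4 `OC(CCN1CC=C(Cc2ccccc2)CC1)c1cccs1` is the next candidate and differs from compound 1 in one place: thiophen-2-yl in place of 4-methylphenyl on a saturated chain carbon bound to an oxygen on a saturated carbon and a saturated chain carbon. Thiophen-2-yl thus replaces 4-methylphenyl on the saturated chain carbon bound to the oxygen. Among the measured compounds shown here, no measured pair shows this change, so direction is uncertain; a small rise in this assay is expected for compound 4, of size a number 10 percentage points higher from compound 1 to compound 4 (within the scatter), though it may fall within the scatter. The estimated value for compound 4 is 40%, with a range from 20% to 65%.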

Compound 4, a percentage reported as inhibition, at one concentration (the size of the read-out at that concentration, not a potency): 52%
Compound 4: middle estimate off by 12 percentage points, on the low side, and the stated range covers the measured number.
By their numbers in this assay, from the lowest: compound 1; then compounds 4, 2 and 3 (each within the scatter of the next, the first and the last beyond it).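

Among these compounds, on the saturated chain carbon bound to the oxygen, thiophen-2-yl in place of 4-methylphenyl gives the first single-place comparison in this assay (a number 22 percentage points higher from compound 1 to compound 4 (beyond the scatter)). The reading at this position therefore depends on the aromatic group it carries, and a five-membered aromatic ring with 1 hetero atom gives more inhibition there than 4-methylphenyl. No measurement at hand accounts for this step. From the compounds shown here alone, whether the sulfur or the smaller ring goes with the rise stays open. Furan-2-yl or unsubstituted phenyl on this carbon would bear on that question.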